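A few compounds are considered here, and "the series" means these few. Any claim that something is new, unique, unknown or untested is made for them only; others in the source may bear on it.

Measured so far:
compound 1, `Cc1ccc(Cn2c(=O)[nH]c3c(N)nc(-c4ncco4)cc32)cn1`: 1.6
compound 2, `CN1CCN(c2ccc(Cn3c(=O)[nH]c4c(N)nc(C(F)(F)F)cc43)cn2)CC1`: 1.8

Of the compounds shown here, two have been measured in a physicochemical assay for lipophilicity, measured as octanol-water partition, at pH 7.4; on this read-out higher numbers stand for higher lipophilicity and lower numbers for lower lipophilicity. Compound 1 gives 1.6 there, and compound 2 gives 1.8. The two numbers lie within the usual scatter of each other, so compound 1 cannot be placed above or below compound 2 on this read-out; the two simply sit close together.

Compound 3, `CCc1coc(-c2cc3c([nH]c(=O)n3Cc3ccc(C)nc3)c(N)n2)n1`, has not yet been measured in this assay. It differs from compound 1 in a single place: ethyl in place of hydrogen on an aromatic carbon. The new group sits on an aromatic carbon of a five-membered aromatic ring with one nitrogen and one oxygen, next to the ring nitrogen; cut one bond further out, the change reads 1,3-oxazol-2-yl to 4-ethyl-1,3-oxazol-2-yl.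

Among the compounds with values here, no pair of measured compounds shows this kind of change, so its size cannot be read off from the numbers above. The expectation is nonetheless a step of a number 0.90 log units higher from compound 1 to compound 3 (beyond the scatter) in this assay, upward and beyond the scatter. Compound 3 is thus estimated at 2.5, within a range from 2.1 to 2.9.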

Compound 3, distribution coefficient: 3.2
The estimate for compound 3 lay 0.70 log units below the measured number; measured number outside the range, above it.
By their numbers in this assay, from the lowest: compounds 1 and 2 (each within the scatter of the next); then compound 3.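

Ethyl in place of hydrogen on this aromatic carbon, next to the ring nitrogen of the five-membered ring, gives a step of a number 1.60 log units higher from compound 1 to compound 3 (beyond the scatter) in this assay and is the first change in a single place that can be read in this series. Its two added carbon atoms are enough to carry the number well beyond the scatter, so this position of the 1,3-oxazol-2-yl group is one where a small alkyl group registers strongly on this read-out. No separate measurement bears on why the step has this size.

Within the data shown here, with only this one step, it remains open whether the step grows in proportion to the chain, as a comparison of methyl, ethyl and a longer propyl chain on the same carbon would show. As far as these compounds go, it also remains open how a group of a different kind at this position, such as an amine or a carboxylic acid, would move the number, and whether ethyl would give a similar step on a different core.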